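A few compounds are considered here, and "the series" means these few. Any claim that something is new, unique, unknown or untested is made for them only; others in the source may bear on it.

Compound 1 `CN(Cc1cn(CC(O)COC(=O)c2ccccc2)nn1)CC1CCCCC1`: 6%
Compound 2 `CC(C)CCN(C)Cc1cn(CC(O)COC(=O)c2ccccc2)nn1`: 0%
Compound 3 `CN(CCCc1ccccc1)Cc1cn(CC(O)COC(=O)c2ccccc2)nn1`: 12%

In an assay on nucleic acid for inhibition of Nucleic Acid, read by fluorescence, tested at 100 uM (on this read-out lower numbers stand for less inhibition and higher numbers for more inhibition at the one concentration tested (going by the name of the read-out)), compound 1 gives 6%, the second highest of the three numbers. Its neighbours lie close: the step of a number 6 percentage points lower from compound 1 to compound 2 (within the scatter) and the step of a number 6 percentage points higher from compound 1 to compound 3 (within the scatter) are both within the scatter, so the three compounds are not told apart with confidence.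

Compound 4 `CCCCNC(=O)OCC(O)Cn1cc(CN(C)CC2CCCCC2)nn1` differs from compound 1 by butylamino in place of phenyl on a carbonyl carbon. Within the data shown here, none of the measured steps touches this part of the molecule; all three exchange groups on the amine side, and the only step beyond the scatter, a number 12 percentage points higher from compound 2 to compound 3 (beyond the scatter), is modest. There is thus no direct guide, and no step beyond the scatter is expected in this assay.

Compound 4 is expected to give 6%, within 0% to 18%, an expected step of no change at the digits printed from compound 1 to compound 4 (within the scatter).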

Compound 4, a percentage reported as inhibition, at one concentration (the size of the read-out at that concentration, not a potency): 12%
Compound 4: middle estimate off by 6 percentage points, on the low side; the range from low to high includes it.
By their numbers in this assay, from the lowest: compounds 2, 1, 3 and 4 (each within the scatter of the next, the first and the last beyond it).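

In this assay, the exchange at this position, butylamino in place of phenyl on a carbonyl carbon, gives a number 6 percentage points higher from compound 1 to compound 4 (within the scatter) and so cannot be told from scatter. Among these compounds, this is the first change away from the amine side of the molecule, and it shows that the six-membered aromatic ring of the benzoyl group can be replaced by an open chain with no measurable effect, although all these numbers are low. No measurement shown offers a reason for this result.

On these data alone, whether a benzylamino or cyclohexylamino group on the same carbonyl carbon would behave like butylamino remains open. So does whether a methylamino group, with its much shorter chain, would give a step beyond the scatter.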